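This account rests on a few compounds, and the source may have more. Where it says the series, first, only, none or still open, it means among the compounds named here.

Compound 1 `C#CCOC(=O)C[C@@H]1C(C(=O)OC)=CO[C@@H](O[C@@H]2O[C@H](COC(C)=O)[C@@H](OC(C)=O)[C@H](OC(C)=O)[C@H]2OC(C)=O)/C1=C/C`: > 15000 nM
Compound 2 `C#CCOC(=O)C[C@@H]1C(C(=O)OC)=CO[C@@H](O[C@@H]2O[C@H](CO)[C@@H](O)[C@H](O)[C@H]2O)/C1=C/C`: > 15000 nM

In a functional assay on SK-BR-3 cells (Homo sapiens) for antiproliferative activity, read by MTT assay, with a stated time of 72 h (a lower number here means a stronger inhibitor, a higher number a weaker inhibitor), compound 1 gives > 15000 nM, which is a limit of the assay. Compound 2 gives > 15000 nM, also a limit and not a number. Compound 2 therefore stands with compound 1 at the limit of > 15000 nM in this assay, at which 2 of the 2 values shown sit.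

Compound 3 `C/C=C1/[C@H](O[C@@H]2O[C@H](CO)[C@@H](O)[C@H](O)[C@H]2O)OC=C(C(=O)OC)[C@H]1CC(=O)OCCc1ccc([N+](=O)[O-])cc1` departs from compound 2 as follows: 4-nitrobenzyl in place of ethynyl on a saturated chain carbon bound to an oxygen next to a carbonyl group. In other words, 4-nitrobenzyl stands in place of ethynyl, or propargyl gives way to 2-(4-nitrophenyl)ethyl. Going by the values given here, no measured step guides this change, so in this assay no shift beyond the scatter is expected, with a slight gain in strength the only likely departure. The expected size is a step that the limit leaves unreadable from compound 2 to compound 3. For compound 3 the estimated value is 18000 nM, with an expected range of 8000 nM to 50000 nM.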

Compound 3, half-maximal inhibitory concentration: > 20000 nM
Compound 3 was reported as a limit (the forecaster's own chance of this, stated with the estimate: 75%); at least 1.1-fold (0.04 log units) between middle value and limit.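

Going by these compounds alone, compound 2 and compound 3 both stand as limits in this assay, not as numbers, so no step between them can be read. The compounds shown leave open whether any group in that place gives a measurable value.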